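This account rests on a few compounds, and the source may have more. Where it says the series, first, only, none or still open, it means among the compounds named here.

Measured so far:
- compound 1, `O=C(Nc1cccc(-c2oc3cc(-c4ccc(F)cc4)ccc3c(=O)c2O)c1)c1ccc(Cl)cc1`: 12800 nM
- compound 2, `COc1ccccc1C(=O)Nc1cccc(-c2oc3cc(-c4ccc(F)cc4)ccc3c(=O)c2O)c1`: 5110 nM
- compound 3, `COc1cc(OC)cc(C(=O)Nc2cccc(-c3oc4cc(-c5ccc(F)cc5)ccc4c(=O)c3O)c2)c1`: 4040 nM

All three were tested in a functional assay on MDA-MB-231 cells (Homo sapiens) for antiproliferative activity, read by CCK-8 assay, with a stated time of 72 h; on this read-out higher numbers stand for weaker inhibition and lower numbers for stronger inhibition. On this read-out compound 3 gives the lowest number of the three: its step from compound 2 is a 1.3-fold lower number from compound 2 to compound 3 (0.10 log units; within the scatter), so these two cannot be told apart, while the step from compound 1 is a 3.2-fold lower number from compound 1 to compound 3 (0.50 log units; beyond the scatter). The three compounds share one core and differ only in the aryl group attached to the amide carbonyl.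

Compound 4, `CCCc1ccc(C(=O)Nc2cccc(-c3oc4cc(-c5ccc(F)cc5)ccc4c(=O)c3O)c2)cc1`, is not yet measured. Its change from compound 3 is 4-propylphenyl in place of 3,5-dimethoxyphenyl on a carbonyl carbon. The measured steps that bear on it are those that swap this same aryl group: a 2.5-fold lower number from compound 1 to compound 2 (0.40 log units; beyond the scatter) and a 3.2-fold lower number from compound 1 to compound 3 (0.50 log units; beyond the scatter), both modest and both lowering the number when methoxy groups enter in place of a chlorine. Compound 4 carries no methoxy groups and returns to a single substituent on the ring, which resembles compound 1 more than compound 3. The expected step is therefore a 2.0-fold higher number from compound 3 to compound 4 (0.30 log units; within the scatter), a rise toward the number of compound 1 rather than a fall. The estimate for compound 4 in this assay is 8000 nM, with a range from 3000 nM to 25000 nM.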

Compound 4, half-maximal inhibitory concentration: 32200 nM
Beside the measured number, compound 4's estimate is 4.0-fold (0.60 log units) below it, and the stated range ends below it.
By their numbers in this assay, from the lowest: compounds 3 and 2 (each within the scatter of the next); then compound 1; then compound 4.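

In this assay, for the compounds shown here, the aryl group on the amide carbonyl turns out to have a wider effect than the earlier compounds suggested: an 8.0-fold higher number from compound 3 to compound 4 (0.90 log units; beyond the scatter) and a 6.3-fold higher number from compound 2 to compound 4 (0.80 log units; beyond the scatter) are both larger than any step among compounds 1, 2 and 3. Methoxy groups are not the only thing that separates these compounds, since a change between two rings without methoxy also matters: with propyl in place of chloro on an aromatic carbon, there is a 2.5-fold higher number from compound 1 to compound 4 (0.40 log units; beyond the scatter) and compound 4 has the highest number of the four. No independent measurement is available here to explain these shifts.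

The compounds shown leave open whether the rise follows the length of the chain, which a 4-ethylphenyl or 4-butylphenyl group in the same place would test. They also leave open how a 4-methoxyphenyl group would compare, which would show whether a single methoxy on the ring is enough to bring the number back down, and how a ring carrying an amine or a carboxylic acid would read.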